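Bromo in place of fluoro in a three-compound series

The source may hold more compounds than are shown below. What is called first, only, known or untested is meant among the compounds shown, and "the series" means these compounds.

In a functional assay on HepG2 cells (Homo sapiens) for antiproliferative activity, read by MTT assay, with a stated time of 24 h (on this read-out higher numbers stand for weaker inhibition and lower numbers for stronger inhibition), compound 1 `O=[N+]([O-])c1ccc(CSc2nnc(-c3ccc4c(c3)OCCO4)n2-c2ccccc2)cc1` gives 13800 nM and compound 2 `COc1cccc(CSc2nnc(-c3ccc4c(c3)OCCO4)n2-c2ccccc2)c1` gives 35100 nM while compound 3 `Fc1ccccc1CSc1nnc(-c2ccc3c(c2)OCCO3)n1-c1ccccc1` gives 810 nM as the lowest of the three numbers. Its lead is wide: the steps of a 17-fold lower number from compound 1 to compound 3 (1.23 log units; beyond the scatter) and a 43-fold lower number from compound 2 to compound 3 (1.64 log units; beyond the scatter) are both large and beyond the scatter.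

Compound 4 `Brc1ccccc1CSc1nnc(-c2ccc3c(c2)OCCO3)n1-c1ccccc1` departs from compound 3 in one place: bromo in place of fluoro on an aromatic carbon with bromo in place of fluoro on an aromatic carbon, ortho to a large group. The 2-fluorobenzyl group thus becomes 2-bromobenzyl.

Among the measured compounds shown here, no measured step exchanges fluoro for bromo, so the evidence is only indirect. All three measured steps change the aryl group at this end of the molecule. The step of a 2.5-fold higher number from compound 1 to compound 2 (0.41 log units; beyond the scatter) is modest, whereas the two steps into compound 3 are large, so the read-out has moved strongly with changes here. For the measured compounds named here, compound 3 is also the only low number among the three, which argues against expecting a further gain.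

A moderate move toward weaker inhibition is therefore expected, and the estimated step is a 3.1-fold higher number from compound 3 to compound 4 (0.49 log units; beyond the scatter) with real uncertainty in its size. In this assay compound 4 is expected at 2500 nM within an estimated range from 600 nM to 12000 nM overall.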

Compound 4, half-maximal inhibitory concentration: 4730 nM
Estimate against measurement, compound 4: 1.9-fold (0.28 log units) below; the range from low to high includes it.
By their numbers in this assay, from the lowest: compound 3; then compound 4; then compound 1; then compound 2.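

In this assay, the step of a 5.8-fold higher number from compound 3 to compound 4 (0.77 log units; beyond the scatter) is the first one shown that changes a single atom on the benzyl ring, with the rest of the aryl group held constant, and it shows that the read-out responds to the identity of the halogen alone. The 2-bromobenzyl group still keeps its number under those of the other two aryl groups, with a 7.4-fold lower number from compound 2 to compound 4 (0.87 log units; beyond the scatter) and a 2.9-fold lower number from compound 1 to compound 4 (0.47 log units; beyond the scatter), so the two halogen-bearing compounds, compound 3 and compound 4, both lie lower than the 3-methoxyphenyl and 4-nitrophenyl compounds, although this rests on only four compounds and the fluoro compound keeps a clear lead. Nothing in the data shown explains why bromo gives a higher number than fluoro here.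

The compounds shown leave open whether chloro or a methyl group on this same aromatic carbon would land between compound 3 and compound 4 or outside that span. They also leave open whether fluoro or bromo would hold its effect on another carbon of the ring, and how an amine or a carboxylic acid would fare on this benzyl group.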